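Hydroxy to amino step carried over to a second core

The source may hold more compounds than are shown below. What is called first, only, known or untested is meant among the compounds shown, and "the series" means these compounds.

Measured compounds in a functional assay on KB cells (Homo sapiens) for antiproliferative activity, read by MTT assay, with a stated time of 72 h; a lower number here means a stronger inhibitor, a higher number a weaker inhibitor:
compound 1, `COc1ccc(-c2ssc(=S)c2-c2cc(OC)c(OC)c(OC)c2)cc1O`, gives 435 nM
compound 2, `COc1ccc(-c2ssc(=S)c2-c2cc(OC)c(OC)c(OC)c2)cc1N`, gives 327 nM
compound 3, `COc1ccc(-c2ss/c(=N/O)c2-c2cc(OC)c(OC)c(OC)c2)cc1O`, gives 850 nM

Compound 1 and compound 2 share a core and differ by amino in place of hydroxy on an aromatic carbon. That change moved the number a 1.3-fold lower number from compound 1 to compound 2 (0.12 log units; within the scatter). Compound 3 carries a second core; the difference between the two cores is not broken down here. Of the three numbers compound 3 stands highest, and compound 2 sits furthest from it, beyond the scatter, while compound 1 sits within it.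

Compound 4, `COc1ccc(-c2ss/c(=N/O)c2-c2cc(OC)c(OC)c(OC)c2)cc1N`, has not been measured. It differs from compound 3 by amino in place of hydroxy on an aromatic carbon, the same change as between compound 1 and compound 2 on the other core, in the same surroundings.

Going by the values given here, the expectation rests on that single earlier pair: with only one step on the first core, the step is expected to repeat, a 1.2-fold lower number from compound 3 to compound 4 (0.08 log units; within the scatter), beside a 1.3-fold lower number from compound 1 to compound 2 (0.12 log units; within the scatter), with wide margins because a 1.3-fold lower number from compound 1 to compound 2 (0.12 log units; within the scatter) lies within the scatter. In this assay compound 4 is therefore estimated at 700 nM, between 350 nM and 1400 nM.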

Compound 4, half-maximal inhibitory concentration: 99 nM
Beside the measured number, compound 4's estimate is 7.1-fold (0.85 log units) above it; measured number outside the range, below it.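

In this assay, the change from 3-hydroxy-4-methoxyphenyl to 3-amino-4-methoxyphenyl gives an 8.6-fold lower number from compound 3 to compound 4 (0.93 log units; beyond the scatter). The size of this step differs between the two cores, so within this series the change cannot be carried from one core to the other as a fixed increment: the same change on two cores in this assay, a 1.3-fold lower number (0.12 log units; within the scatter) from compound 1 to compound 2 and an 8.6-fold lower number (0.93 log units; beyond the scatter) from compound 3 to compound 4, 6.5-fold (0.81 log units) apart, beyond the scatter of two such steps

This comparison rests on a single pair on each core, so it gives no reason for the difference and no guide to the size of the step on a third core. The compounds shown leave open whether a methylamino or an acetamido group in place of the amino group would give a similar result on either core. Also open, from the compounds shown here alone, is whether the gap between the two steps would persist with an ethoxy group in place of the methoxy group.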